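A few compounds are considered here, and "the series" means these few. Any claim that something is new, unique, unknown or untested is made for them only; others in the source may bear on it.

Working notes on the series. Three amides on the shared core have been run in an ADME assay on MRC5 cells (Homo sapiens) for cytotoxicity, read by MTT assay, with a stated time of 72 h; on this read-out higher numbers stand for weaker inhibition and lower numbers for stronger inhibition. Compound 1 `O=C(Nc1nnc(-c2cccc(O)c2O)s1)c1ccccc1` gives 23200 nM, compound 3 `O=C(Nc1nnc(-c2cccc(O)c2O)s1)C1CCCCC1` gives 70300 nM, and compound 2 `O=C(Nc1nnc(-c2ccc(O)c(O)c2)s1)C1CCCCC1` gives 24000 nM. Compound 2 stands second highest of the three numbers: its value and that of compound 1 lie within the scatter of one another, while the number for compound 3 lies higher than that for compound 2 by more than the scatter. Compound 4 `O=C(Nc1nnc(-c2ccc(O)c(O)c2)s1)c1ccccc1` has not yet been measured. It differs from compound 2 in one place: phenyl in place of cyclohexyl on a carbonyl carbon. Among the measured compounds shown here, the single measured step that bears on this exchange is the same change run in the opposite direction, a 3.0-fold higher number from compound 1 to compound 3 (0.48 log units; beyond the scatter), a modest step beyond the scatter. Reading that step backwards, the expectation for compound 4 is a step of a 2.7-fold lower number from compound 2 to compound 4 (0.43 log units; beyond the scatter), a lower number than compound 2 shows and beyond the scatter. For the measured compounds named here, only one such step is available, and the two pairs differ in where the hydroxyls sit, so the range is kept wide. In this assay compound 4 is therefore estimated at 9000 nM, expected to fall between 4000 nM and 22000 nM.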

Compound 4, half-maximal inhibitory concentration: 27400 nM
The estimate for compound 4 lay 3.0-fold (0.48 log units) below the measured number; measured number outside the range, above it.
By their numbers in this assay, from the lowest: compounds 1, 2 and 4 (each within the scatter of the next); then compound 3.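

In this assay, phenyl in place of cyclohexyl on a carbonyl carbon gives a 1.1-fold higher number from compound 2 to compound 4 (0.06 log units; within the scatter), so on the core of compound 2 this position does not distinguish the two rings within the resolution of the read-out. The earlier compounds shown here showed this exchange on one core only, and it now reads differently on the two cores, which differ in where the hydroxyls sit: the same change on two cores in this assay, a 3.0-fold higher number (0.48 log units; beyond the scatter) from compound 1 to compound 3 and a 1.1-fold lower number (0.06 log units; within the scatter) from compound 4 to compound 2, 3.5-fold (0.54 log units) apart, beyond the scatter of two such steps. A separation between the phenyl and cyclohexyl amides is therefore seen on the core of compound 1 alone, and the step measured there cannot be treated as a general value for this exchange.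

The compounds shown leave open whether the same dependence on the core would appear with other groups on the carbonyl carbon, such as a longer alkyl chain, a piperidine ring or a carboxylic acid carried on a short chain. Also open, on these data alone, is how either ring would read on a core with methoxy groups in place of the two hydroxyls, as each exchange here rests on a single pair of compounds.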